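Tert-butylamino for fluoro on the cyano-bearing core

The source may hold more compounds than are shown below. What is called first, only, known or untested is meant among the compounds shown, and "the series" means these compounds.

Working notes on a small set of diaminoquinazoline-type nitriles tested in a functional assay on A549 cells (Homo sapiens) for cytotoxicity, read by MTT assay; on this read-out lower numbers stand for stronger inhibition and higher numbers for weaker inhibition. Compound 1 `N#Cc1c(Cl)c(Cl)c2nc(N)nc(N)c2c1Cl` gives 29.7 ug/mL in this assay. Compound 2 `N#Cc1c(F)c(Cl)c2nc(N)nc(N)c2c1F` gives 30.8 ug/mL in this assay, the higher of the two numbers, though its gap to compound 1 sits within the usual scatter, so the two cannot be told apart. Compound 3 `N#Cc1c(NCc2ccccc2)c(F)c2nc(N)nc(N)c2c1F` carries a benzylamino group and a second fluoro in place of the chloro; in this assay compound 3 gives only a limit, > 1000 ug/mL, and no number. Going by the values given here, that one limit, (the limit of > 1000 ug/mL in this assay, at which 1 of the 3 values shown sits), is the only evidence beyond the two close numbers.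

Compound 4 `CC(C)(C)Nc1c(C#N)c(F)c2c(N)nc(N)nc2c1Cl` has not yet been measured in this assay. Against compound 2 the change is (tert-butyl)amino in place of fluoro on an aromatic carbon, with the chloro and the second fluoro exchanged as well. Among the compounds with values here, the single amine-bearing analogue on record, compound 3, sits at a limit, so a move in the weaker direction, beyond the scatter, is expected, with a real chance of another limit. The step from compound 2 to compound 4 is estimated at a 9.7-fold higher number from compound 2 to compound 4 (0.99 log units; beyond the scatter). For compound 4 the expected value in this assay is 300 ug/mL, within a range of 60 ug/mL to 1000 ug/mL.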

Compound 4, half-maximal inhibitory concentration: 313 ug/mL
Compound 4: middle estimate off by 1.0-fold (0.02 log units), on the low side, and the stated range covers the measured number.
By their numbers in this assay, from the lowest: compounds 1 and 2 (each within the scatter of the next); then compound 4. At a limit, above all of these: compound 3.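

In this assay, going by these compounds alone, the position ortho to the chloro and cyano groups proves sensitive to the exchange of fluoro for (tert-butyl)amino, with a 10-fold higher number from compound 2 to compound 4 (1.01 log units; beyond the scatter); this is the first single-place step, and it is large. The earlier compounds shown here gave no such reading: compounds 1 and 2 stand within the scatter of each other and share no single-place step with an amine-bearing compound. Compound 4 also shows that an amine-bearing member of this series can give a true number in this assay, whereas compound 3, which carries benzylamino and differs from compound 4 in more than one place, remains a limit and not a number: the limit of > 1000 ug/mL in this assay, at which 1 of the 4 values shown sits.

Within the data shown here, the single step cannot separate the contribution of the nitrogen link from that of the tert-butyl group, and an amino or methylamino group in place of fluoro at this position would be needed to tell the two apart. On these data alone, whether a change of the same kind behaves alike on the core of compound 1, where chloro stands in place of each fluoro, also stays open.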